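Cytotoxicity of an Imidazole Series After a Benzyl Swap

The source may hold more compounds than are shown below. What is called first, only, known or untested is meant among the compounds shown, and "the series" means these compounds.

This set of compounds is examined in a toxicity assay on NIH3T3 cells (Mus musculus) for cytotoxicity, read by resazurin assay; on this read-out higher numbers stand for an effect only at larger amounts of compound and lower numbers for an effect already at smaller amounts. Compound 1, `Nc1cc(-c2ccccc2)ccc1Cn1cncc1CNc1ccc(-c2cncs2)c(-c2ccccc2)c1`, gives a limit rather than a number in this assay, > 1000 nM. Compound 3, `O=[N+]([O-])c1ccc(Cn2cncc2CNc2cccc(-c3ccccc3)c2)cc1`, gives 10000 nM in this assay. Compound 2, `COC(=O)c1ccc(NCc2cncn2Cc2ccc(C(C)(C)C)cc2)cc1-c1ccccc1`, has no result in this assay: "not determined" (no result reported). So compound 2 stands nowhere on the numbers shown; the only neighbouring information is that (the limit of > 1000 nM in this assay, at which 1 of the 3 values shown sits), and that compound 3 reaches a high concentration before any effect appears.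

Compound 4, `COC(=O)c1ccc(NCc2cncn2Cc2ccccc2C)cc1-c1ccccc1`, is the next compound to be measured. It differs from compound 2 in one place: 2-methylphenyl in place of 4-(tert-butyl)phenyl on a saturated chain carbon bound to an aromatic nitrogen. Among the measured compounds shown here, no measured step between compounds is available here, so the size of the change cannot be read from a comparison. For compound 4 in this assay a result at the same high end as compound 3 is expected, with no step beyond the usual scatter from what is seen around it. The expected value for compound 4 is 10000 nM, within a range of 3000 nM to 30000 nM.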

Compound 4, half-maximal effective concentration: 10000 nM
Compound 4: the middle estimate sits on the measured number at the digits printed; the measured number falls inside the stated range.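

Compound 2 has no number in this assay, so no step can be read between compound 2 and compound 4. The compounds shown leave open what the change from 4-(tert-butyl)benzyl to 2-methylbenzyl does to this read-out, and one value remains only a limit: the limit of > 1000 nM in this assay, at which 1 of the 4 values shown sits.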